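A few compounds are considered here, and "the series" means these few. Any claim that something is new, unique, unknown or untested is made for them only; others in the source may bear on it.

Of the compounds shown here, three built on one shared core have been tested in a functional assay on HeLa cells (Homo sapiens) for antiproliferative activity, read by CCK-8 assay, with a stated time of 72 h, tested at 2 uM; a lower number here means a weaker effect, a higher number a stronger effect of the compound at the concentration tested. Compound 1 `Nc1ccccc1NC(=O)c1ccc(CSC(=S)N2CCN(c3ccc(F)cc3)CC2)cc1` gives 60.8%. Compound 2 `Nc1ccccc1NC(=O)c1ccc(CSC(=S)N2CCN(Cc3ccncc3)CC2)cc1`, which carries (pyridin-4-yl)methyl in place of 4-fluorophenyl on an amine nitrogen in a ring, gives 59.5%. Compound 3 `CN1CCN(C(=S)SCc2ccc(C(=O)Nc3ccccc3N)cc2)CC1`, with methyl on that amine nitrogen in a ring, gives 52.6%; this is the lowest of the three numbers shown, yet both others sit within the scatter of it, as the steps of a number 8.2 percentage points lower from compound 1 to compound 3 (within the scatter) and a number 6.9 percentage points lower from compound 2 to compound 3 (within the scatter) make clear. Compound 4 `Nc1ccccc1NC(=O)c1ccc(CSC(=S)N2CCN(Cc3ccccc3)CC2)cc1` has not been measured. It differs from compound 3 in that (phenyl in place of hydrogen on a saturated chain carbon bound to an amine nitrogen in a ring). The step bearing most directly on this change is a number 6.9 percentage points lower from compound 2 to compound 3 (within the scatter), where a ring group on the same saturated chain carbon was exchanged for hydrogen, and a number 1.3 percentage points lower from compound 1 to compound 2 (within the scatter) shows that swapping groups on this amine nitrogen in a ring also moved little. Among the compounds with values here, since no step here left the scatter, the expected step is a number 4.4 percentage points higher from compound 3 to compound 4 (within the scatter), none beyond the scatter. Compound 4 is accordingly estimated at 57%, with a range from 45% to 69%.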

Compound 4, a percentage reported as inhibition, at one concentration (the size of the read-out at that concentration, not a potency): 20.6%
Estimate against measurement, compound 4: 36.4 percentage points above; measured number outside the range, below it.
By their numbers in this assay, from the lowest: compound 4; then compounds 3, 2 and 1 (each within the scatter of the next).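

In this assay this amine nitrogen in a ring no longer looks tolerant of any group: the change from methyl to benzyl brings a number 32 percentage points lower from compound 3 to compound 4 (beyond the scatter) and is large, beyond the scatter. The ring on the saturated chain carbon matters as well as its presence, since phenyl in place of pyridin-4-yl gives a number 38.9 percentage points lower from compound 2 to compound 4 (beyond the scatter) and benzyl in place of 4-fluorophenyl gives a number 40.2 percentage points lower from compound 1 to compound 4 (beyond the scatter) and leaves compound 4 lowest of the four. Nothing measured here explains this drop.

Still open, from the compounds shown here alone, is whether a fluorine, a methoxy group or an amine on the benzyl ring would bring the number back toward those of compound 1 and compound 2. A longer chain between the ring nitrogen and the phenyl ring, as in 2-phenylethyl, also remains untested among the compounds shown.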